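The compounds below may be only part of what the source reports. "The series", "measured", "known", "first", "only" and "open" are said of these compounds alone.

Measured compounds:
Compound 1, `COc1ccc(-c2cc(NC(=O)CCC(=O)NCC(=O)NC(C)(C)C)nc(-c3ccc(OC)cc3)n2)cc1`: 36700 nM
Compound 2, `COc1ccc(-c2cc(NC(=O)CCC(=O)NCC(=O)NC3CCCCC3)nc(-c3ccc(OC)cc3)n2)cc1`: 74200 nM
Compound 3, `COc1ccc(-c2cc(NC(=O)COCC(=O)N(C)CC(=O)NC(C)(C)C)nc(-c3ccc(OC)cc3)n2)cc1`: 19400 nM

The three compounds were tested in an assay on HeLa cells for displacement of a labelled ligand from adenosine receptor A3 (Homo sapiens), read by fluorescence polarization, with a stated time of 30 min; on this read-out higher numbers stand for weaker inhibition and lower numbers for stronger inhibition. Compound 1 and compound 2 share a core and differ in one place, (cyclohexyl in place of tert-butyl on an amide-type nitrogen); that change gave a 2.0-fold higher number from compound 1 to compound 2 (0.31 log units; beyond the scatter). Compound 3 has a different core, and the difference between its core and the core of compound 1 is not broken down here. In this assay compound 3 gives 19400 nM, the lowest of the three numbers, though its gap to compound 1 lies within the scatter and only its gap to compound 2 lies beyond it.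

Compound 4, `COc1ccc(-c2cc(NC(=O)COCC(=O)N(C)CC(=O)NC3CCCCC3)nc(-c3ccc(OC)cc3)n2)cc1`, has not yet been measured. It differs from compound 3 by cyclohexyl in place of tert-butyl on an amide-type nitrogen, the same change that turned compound 1 into compound 2. Because a 2.0-fold higher number from compound 1 to compound 2 (0.31 log units; beyond the scatter) was a modest step beyond the scatter, the same change on the core of compound 3 is expected to give a step of similar size, a 2.0-fold higher number from compound 3 to compound 4 (0.30 log units; within the scatter). Compound 4 is therefore estimated to give 39000 nM in this assay, with a likely range from 16000 nM to 95000 nM.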

Compound 4, inhibition constant: 23700 nM
Beside the measured number, compound 4's estimate is 1.6-fold (0.22 log units) above it; measured number inside the range.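

In this assay, putting cyclohexyl in place of tert-butyl on the amide-type nitrogen gave a 1.2-fold higher number from compound 3 to compound 4 (0.09 log units; within the scatter), so on this core the two groups cannot be told apart, whereas on the core of compound 1 the step lay just beyond the scatter. Set side by side, the two steps do not differ measurably: the same change on two cores in this assay, a 2.0-fold higher number (0.31 log units; beyond the scatter) from compound 1 to compound 2 and a 1.2-fold higher number (0.09 log units; within the scatter) from compound 3 to compound 4, 1.7-fold (0.22 log units) apart, within the scatter of two such steps. The change therefore carries over from one core to the other as far as this assay can resolve, but two pairs do not show that the step is truly the same size on both cores, nor that it would hold on any other core.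

The compounds shown leave open how other groups on that amide-type nitrogen would read, such as a methyl, a benzyl or a chain ending in an amine or a carboxylic acid. They also leave open which part of the difference between the two cores matters, as no pair shown isolates any part of it.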